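Aryl exchange on nitrogen: compound 1 to compound 4

A few compounds are considered here, and "the series" means these few. Any claim that something is new, unique, unknown or untested is made for them only; others in the source may bear on it.

In a functional assay on A549 cells (Homo sapiens) for cytotoxicity, read by MTT assay, with a stated time of 72 h (on this read-out higher numbers stand for weaker inhibition and lower numbers for stronger inhibition), compound 1 `Cn1ccc2c(Oc3ccc(NC(=O)c4cc5cccnc5n(-c5ccccc5)c4=O)cc3)ncnc21` gives 66200 nM. Compound 2 `Cn1ccc2c(Oc3ccc(NC(=O)c4cc5cccnc5n(-c5ccc(Cl)cc5)c4=O)cc3)ncnc21` gives 75500 nM, and compound 3 `COc1ccc(-n2c(=O)c(C(=O)Nc3ccc(Oc4ncnc5c4ccn5C)cc3)cc3cccnc32)cc1` gives 83200 nM. Compound 1 thus stands within the scatter of both other compounds, and the three numbers form a single flat group with no meaningful order.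

Compound 4 `Cn1ccc2c(Oc3ccc(NC(=O)c4cc5cccnc5n(-c5ccc(C(F)(F)F)cc5Cl)c4=O)cc3)ncnc21` keeps the core of compound 1 and changes only the aryl group: 2-chloro-4-(trifluoromethyl)phenyl in place of phenyl on an aromatic nitrogen, (2-chloro-4-(trifluoromethyl)phenyl in place of phenyl on an aromatic nitrogen).

For the measured compounds named here, three measured steps bear on this change. Chloro in place of hydrogen gives a 1.1-fold higher number from compound 1 to compound 2 (0.06 log units; within the scatter), methoxy in place of hydrogen gives a 1.3-fold higher number from compound 1 to compound 3 (0.10 log units; within the scatter), and methoxy in place of chloro gives a 1.1-fold higher number from compound 2 to compound 3 (0.04 log units; within the scatter). All three stay within the scatter, so single substitution on this phenyl has not yet moved the read-out. Going by the values given here, no measured compound carries trifluoromethyl or a phenyl with two substituents, so the evidence covers the new group only in part.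

No shift beyond the scatter is expected in this assay, in either direction, although the uncertainty is wider than for a single substitution. The estimated change is a 1.0-fold lower number from compound 1 to compound 4 (0.01 log units; within the scatter).

For compound 4 the expected value is 65000 nM, within an estimated range of 28000 nM to 120000 nM.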

Compound 4, half-maximal inhibitory concentration: 364000 nM
Beside the measured number, compound 4's estimate is 5.6-fold (0.75 log units) below it; the whole stated range lies below it.
By their numbers in this assay, from the lowest: compounds 1, 2 and 3 (each within the scatter of the next); then compound 4.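

In this assay, the aryl group on the aromatic nitrogen now moves the read-out beyond the scatter, towards weaker inhibition: a 5.5-fold higher number from compound 1 to compound 4 (0.74 log units; beyond the scatter), a 4.8-fold higher number from compound 2 to compound 4 (0.68 log units; beyond the scatter) and a 4.4-fold higher number from compound 3 to compound 4 (0.64 log units; beyond the scatter). This position is therefore not indifferent to its aryl group: phenyl, 4-chlorophenyl and 4-methoxyphenyl form one flat group, while 2-chloro-4-(trifluoromethyl)phenyl stands apart from all three. No measurement at hand accounts for this shift.

Compound 4 carries the chloro and the trifluoromethyl of 2-chloro-4-(trifluoromethyl)phenyl together, and the compounds shown do not separate the contribution of each, or show whether the shift needs both. Also open, on these data alone, is how an amine or a carboxylic acid on this phenyl would read in this assay, and whether any group here could give stronger inhibition than the flat group of compounds 1, 2 and 3.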